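The source may report more compounds than this note shows. Statements on the series, on what has been measured and on what is new or still open speak of the compounds shown alone.

Measured so far in an ADME assay on MT2 cells (Homo sapiens) for cytotoxicity, read by XTT assay, with a stated time of 4 days; a lower number here means that less compound is tolerated, a higher number that more compound is tolerated:
- compound 1 `Cc1cc(/C=C2\SC(=S)N(c3ccccc3)C2=O)c(C)n1-c1cccc(-c2nnn[nH]2)c1` gives 61000 nM
- compound 2 `COc1cccc(N2C(=O)/C(=C/c3cc(C)n(-c4cccc(-c5nnn[nH]5)c4)c3C)SC2=S)c1` gives 40600 nM
- compound 3 `Cc1cc(/C=C2\SC(=S)N(c3cccc(C(F)(F)F)c3)C2=O)c(C)n1-c1cccc(-c2nnn[nH]2)c1` gives 15800 nM

Compound 3 holds the lowest number of the three in this assay. Its nearest neighbour is compound 2, and the step of a 2.6-fold lower number from compound 2 to compound 3 (0.41 log units; beyond the scatter) lies beyond the scatter, as does the larger step of a 3.9-fold lower number from compound 1 to compound 3 (0.59 log units; beyond the scatter). Between compound 1 and compound 2 the step of a 1.5-fold lower number from compound 1 to compound 2 (0.18 log units; within the scatter) stays within the scatter, so those two cannot be ordered against each other.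

Compound 4 `Cc1cc(/C=C2\SC(=S)N(c3cccc(O)c3)C2=O)c(C)n1-c1cccc(-c2nnn[nH]2)c1` is not yet measured. It differs from compound 3 by hydroxy in place of trifluoromethyl on an aromatic carbon. Within the data shown here, two measured steps bear on this change, both ending at compound 3: a 3.9-fold lower number from compound 1 to compound 3 (0.59 log units; beyond the scatter) and a 2.6-fold lower number from compound 2 to compound 3 (0.41 log units; beyond the scatter). In each, trifluoromethyl at this aromatic carbon goes with a modestly lower number than hydrogen or methoxy there. Hydroxy itself has no precedent in the set, so removing trifluoromethyl is read as reversing most of that effect rather than all of it. For compound 4 the expected step is a 2.8-fold higher number from compound 3 to compound 4 (0.45 log units; beyond the scatter). Compound 4 is therefore estimated at 45000 nM in this assay, with a range from 20000 nM to 100000 nM.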

Compound 4, half-maximal cytotoxic concentration: 35600 nM
For compound 4 the middle estimate is 1.3-fold (0.10 log units) above the measured one; the measured number falls inside the stated range.
By their numbers in this assay, from the lowest: compound 3; then compounds 4, 2 and 1 (each within the scatter of the next).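

In this assay, hydroxy in place of trifluoromethyl on this aromatic carbon gives a 2.3-fold higher number from compound 3 to compound 4 (0.35 log units; beyond the scatter) and so leaves compound 3 alone at the low end of the series, now set apart from three other groups at this carbon rather than two. The hydroxy compound cannot be separated from the hydrogen or methoxy compounds, as both a 1.7-fold lower number from compound 1 to compound 4 (0.23 log units; within the scatter) and a 1.1-fold lower number from compound 2 to compound 4 (0.06 log units; within the scatter) stay inside the usual scatter, and compounds 1, 2 and 4 therefore cannot be ordered against one another. Among the four compounds, only the 3-(trifluoromethyl)phenyl group goes with a number clearly apart from the rest, while the hydrogen-bond donor that hydroxy brings does not distinguish compound 4 from compound 1 or compound 2.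

On these data alone, whether the lower number belongs to trifluoromethyl alone remains open, and a chlorine, a nitrile, an amine or a carboxylic acid on this aromatic carbon would test that. No measurement at hand accounts for the separate standing of compound 3.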